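The source may hold more compounds than are shown below. What is called first, only, known or untested is meant among the compounds shown, and "the series" means these compounds.

Measured so far: compound 1 `CC[C@@H](Nc1c(C#N)c(-c2ccc(-c3ccccc3NC)cc2)nc2cnccc12)C(N)=O` with 2.5; compound 2 `CN(CC(N)=O)c1c(C#N)c(-c2ccc(Br)cc2)nc2cnccc12` with 2.1; compound 3 `CCOc1ccccc1-c1ccc(-c2nc3cncc(Cl)c3c(N[C@H](CC)C(N)=O)c2C#N)cc1` with 3.7.

In a physicochemical assay for lipophilicity, read by HPLC, at pH 7.5 (a lower number here means a more polar compound, a higher number a more lipophilic compound), compound 1 gives 2.5, the second highest of the three numbers: compound 2 sits lower, beyond the scatter, and compound 3 sits higher, also beyond the scatter. Compound 4 `CC[C@@H](Nc1c(C#N)c(-c2ccc(-c3cccc(Cl)c3OC)cc2)nc2cnccc12)C(N)=O` differs from compound 1 in one place, (3-chloro-2-methoxyphenyl in place of 2-(methylamino)phenyl on an aromatic carbon). For the measured compounds named here, no measured pair shows exactly this change, so its size is not known. The nearest guide is compound 3, which carries an alkoxy group on the outer ring and gives 3.7, pointing upward. The step from compound 1 to compound 4 is therefore expected to be upward and beyond the scatter, a number 0.80 log units higher from compound 1 to compound 4 (beyond the scatter). Compound 4 is expected to give 3.3, within 2.8 to 3.8.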

Compound 4, distribution coefficient: 3.1
Compound 4: the middle estimate sits 0.20 log units above what was measured; the measured number falls inside the stated range.
By their numbers in this assay, from the lowest: compound 2; then compound 1; then compound 4; then compound 3.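

In this assay, for the compounds shown here, placing 3-chloro-2-methoxyphenyl in place of 2-(methylamino)phenyl on this aromatic carbon gives the first direct reading of a change at this position: a number 0.60 log units higher from compound 1 to compound 4 (beyond the scatter). The entering group has 0 hydrogen-bond donors and the leaving group has 1, but this single step does not separate the contribution of the chlorine from that of the methoxy group. Nothing measured here accounts for the step.

The compounds shown leave open how 2-methoxyphenyl without the chlorine would read at this position. They also leave open what a carboxylic acid or a dimethylamino group on the outer ring would give.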